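This account rests on a few compounds, and the source may have more. Where it says the series, first, only, none or still open, it means among the compounds named here.

The measured compounds:
Compound 1, `Nc1cc(N)c2nc(-c3ccccc3)c(NCc3ccc(Cl)c(Cl)c3)nc2c1`: 6920 nM
Compound 2, `Nc1cc(N)c2nc(-c3ccccc3)c(NCc3ccc(F)cc3)nc2c1`: 6460 nM
Compound 3, `COc1ccc(CNc2nc3cc(N)cc(N)c3nc2-c2ccccc2)cc1`: 7760 nM

All three share one core and differ only in the aryl group carried on a saturated chain carbon bound to a nitrogen on an aromatic ring. In a functional assay on OVCAR-3 cells (Homo sapiens) for inhibition, read by sulforhodamine B assay, with a stated time of 48 h (a lower number here means a stronger inhibitor of growth, a higher number a weaker inhibitor of growth), compound 2 gives the lowest of the three numbers, yet the step of a 1.1-fold lower number from compound 1 to compound 2 (0.03 log units; within the scatter) and the step of a 1.2-fold higher number from compound 2 to compound 3 (0.08 log units; within the scatter) both fall within the scatter, so no order can be read among the three.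

Compound 4, `Nc1cc(N)c2nc(-c3ccccc3)c(Sc3ccc(Cl)c(Cl)c3)nc2c1`, has not yet been measured in this assay. It differs from compound 2 by (3,4-dichlorophenyl)sulfanyl in place of (4-fluorobenzyl)amino on an aromatic carbon. Going by the values given here, two measured steps bear on the aryl part of this change: a 1.1-fold lower number from compound 1 to compound 2 (0.03 log units; within the scatter), which exchanges 3,4-dichlorophenyl for 4-fluorophenyl on a saturated chain carbon bound to a nitrogen on an aromatic ring, and a 1.1-fold higher number from compound 1 to compound 3 (0.05 log units; within the scatter), which puts 4-methoxyphenyl there instead. Both lie within the scatter. Among the compounds with values here, no measured pair exchanges the linking group itself, so that half of the change has nothing to go on. On the aryl side nothing beyond the scatter is indicated, and compound 4 is therefore expected to land near compound 2, with a range widened for the untested linker: 7000 nM, between 3000 nM and 17000 nM, an expected step of a 1.1-fold higher number from compound 2 to compound 4 (0.03 log units; within the scatter).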

Compound 4, concentration for total growth inhibition: 46800 nM
Beside the measured number, compound 4's estimate is 6.7-fold (0.83 log units) below it; the whole stated range lies below it.
By their numbers in this assay, from the lowest: compounds 2, 1 and 3 (each within the scatter of the next); then compound 4.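

In this assay, going by these compounds alone, the aryl exchanges among compounds 1, 2 and 3 all stayed within the scatter, whereas a 7.2-fold higher number from compound 2 to compound 4 (0.86 log units; beyond the scatter) is the first step beyond it, showing that this aromatic carbon does respond when the whole substituent is changed. The 3,4-dichlorophenyl group does not by itself bring the higher number: compound 1 carries that group and gives 6920 nM, while compound 4 carries it on sulfur and gives 46800 nM, so the difference goes with the link rather than with the aryl ring. Nothing available accounts for this difference.

The compounds shown leave open whether it follows from the sulfur, from the saturated chain carbon present in compound 1 and absent from compound 4, or from the nitrogen-bound hydrogen that is also lost. On these data alone, a benzylsulfanyl group, a phenylamino group or a phenoxy group at this position would separate these three changes, and whether a 4-fluorophenyl or 4-methoxyphenyl group on sulfur would give a number near that of compound 4 also remains unknown.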